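Swapping the Pyrrolidinyl Ketone for an Aryl Ketone

A few compounds are considered here, and "the series" means these few. Any claim that something is new, unique, unknown or untested is made for them only; others in the source may bear on it.

Compound 1 `O=C(/C(=C\c1ccc(O)c([N+](=O)[O-])c1)SCc1ccc(Br)cc1)C1CCNC1` was tested in a functional assay on DU-145 cells (Homo sapiens) for inhibition, read by trypan blue exclusion, with a stated time of 96 h; on this read-out higher numbers stand for weaker inhibition of growth and lower numbers for stronger inhibition of growth. Compound 1 gives > 100000 nM, which is a limit of the assay rather than a number, so compound 1 sits at the limit of > 100000 nM in this assay, at which 1 of the 2 values shown sits. Compound 2 `O=C(/C(=C\c1ccc(O)c([N+](=O)[O-])c1)S(=O)(=O)Cc1ccc(Br)cc1)c1ccc(Br)cc1` gives 10000 nM in this assay, a measurable value. Compound 3 `N#Cc1ccc(C(=O)/C(=C\c2ccc(O)c([N+](=O)[O-])c2)SCc2ccc(Br)cc2)cc1` differs from compound 1 in one place: 4-cyanophenyl in place of pyrrolidin-3-yl on a carbonyl carbon. Among the compounds with values here, no measured pair shows this exact change. The step of an at least 6.6-fold lower number from compound 1 to compound 3 (0.82 log units; beyond the scatter) is expected to move beyond the usual scatter toward stronger inhibition of growth. Compound 3 is expected to give 15000 nM, with a range from 3000 nM to 100000 nM in this assay.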

Compound 3, concentration for 50% growth inhibition: 10000 nM
Compound 3: the middle estimate sits 1.5-fold (0.18 log units) above what was measured, and the stated range covers the measured number.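

On the carbonyl carbon, 4-cyanophenyl in place of pyrrolidin-3-yl brings growth inhibition to a measurable value in this assay: the change gives an at least 10-fold lower number from compound 1 to compound 3 (1.00 log units; beyond the scatter) in this first pair differing in one place. Compound 1 is held at a limit of the assay, not a number, so the full size of the step stays unknown: the limit of > 100000 nM in this assay, at which 1 of the 3 values shown sits.

On these data alone, whether a plain phenyl or a 4-methoxyphenyl group on the same carbonyl carbon would do as well as 4-cyanophenyl stays open. So does the outcome with a 4-carboxyphenyl group there.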